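The source may report more compounds than this note shows. Statements on the series, on what has been measured and on what is new or still open speak of the compounds shown alone.

Compound 1 `O=C1NC(=O)C(c2ccc(Cl)cc2)(C2CC2)N1` gives 85 mg/kg in a functional assay on the whole organism (strain Sprague-Dawley albino) with Rattus norvegicus as the target; a higher number here means that more compound is needed for the effect, a lower number that less compound is needed.
Compound 2 `O=C(OCc1ccccc1)N1CCN(CN2C(=O)NC(c3ccccc3)(C3CC3)C2=O)CC1` is recorded as "not determined" (no result reported) in this assay.

The study reports a single number. In this assay, for the measured compounds named here, compound 1 gives 85 mg/kg, and this is the only value available, since compound 2 carries no result in this assay. Going by the values given here, compound 1 therefore stands alone; there is no second measured compound against which to place it, and no step between measured compounds can be read from these data.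

Compound 3 `O=C1NC(=O)C(c2ccccc2)(C2CC2)N1` has not yet been tested. It differs from compound 1 in one place: hydrogen in place of chloro on an aromatic carbon. Because compound 1 reaches its effect at 85 mg/kg, the expectation for compound 3 rests on that one value and on the loss of the chloro group alone. Compound 3 is expected to need somewhat more compound, with the step of a 1.5-fold higher number from compound 1 to compound 3 (0.18 log units; within the scatter) estimated to be small and likely not far beyond the scatter. The estimate for compound 3 in this assay is 130 mg/kg, within a range of 55 mg/kg to 310 mg/kg.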

Compound 3, dose for half-maximal effect in the Rattus norvegicus assay: 57.3 mg/kg
Compound 3: the middle estimate sits 2.3-fold (0.36 log units) above what was measured, and the stated range covers the measured number.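

In the Rattus norvegicus assay the step is a 1.5-fold lower number from compound 1 to compound 3 (0.17 log units; within the scatter), so compound 1 and compound 3 cannot be told apart by dose, and the effect does not depend on the chloro group at this position, para to a large group. In a physicochemical assay for lipophilicity (a higher number here means a more lipophilic compound, a lower number a more polar compound), compound 1 gives 2.63 and compound 3 gives 1.66. The exchange of chloro for hydrogen therefore makes compound 3 the more polar of the pair while the dose stays within the scatter, a separation that the single earlier value could not show: the measured partition coefficient of compound 1, 2.63, and of compound 3, 1.66, a number 0.97 log units lower (beyond the scatter)

The compounds shown leave open whether a different group on this aromatic carbon, such as a methoxy group or an amine, would also leave the dose within the scatter. Steps involving compound 2 cannot be read, as it carries no result.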